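Methyl to phenyl on the five-membered aromatic ring

A few compounds are considered here, and "the series" means these few. Any claim that something is new, unique, unknown or untested is made for them only; others in the source may bear on it.

Measured so far in an in vivo functional assay on the whole organism for inhibition of 3-hydroxy-3-methylglutaryl-coenzyme A reductase (Rattus norvegicus), at a dose of 0.2 mg/kg by the oral route; a lower number here means a weaker effect, a higher number a stronger effect of the compound at the dose given:
- compound 1 `Cc1nn(C(C)(C)C)c2nc(C3CC3)c(/C=C/[C@@H](O)C[C@@H](O)CC(=O)O)c(-c3ccc(F)cc3)c12`: 4.5%
- compound 2 `Cc1nn(C)c2nc(C3CC3)c(/C=C/[C@@H](O)C[C@@H](O)CC(=O)O)c(-c3ccc(F)cc3)c12`: 35.5%

Compound 2 stands highest of the two numbers in this assay; its nearest neighbour is compound 1, and the step of a number 31 percentage points higher from compound 1 to compound 2 (beyond the scatter) lies beyond the scatter. That step is the only one available, and it concerns a group on an aromatic nitrogen.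

Compound 3 `Cn1nc(-c2ccccc2)c2c(-c3ccc(F)cc3)c(/C=C/[C@@H](O)C[C@@H](O)CC(=O)O)c(C3CC3)nc21` has not yet been measured in this assay. It differs from compound 2 as follows: phenyl in place of methyl on an aromatic carbon. Going by the values given here, the change sits on an aromatic carbon of the five-membered aromatic ring, a different place from the one altered between compound 1 and compound 2, so the measured step of a number 31 percentage points higher from compound 1 to compound 2 (beyond the scatter) bears on it only loosely. It shows that this ring tolerates a change of substituent with a large effect on inhibition, but gives no direction for the present exchange.

Compound 3 is therefore expected to give 25% in this assay, within 5% to 55%. The expected step of a number 10.5 percentage points lower from compound 2 to compound 3 (beyond the scatter) is an estimate only, with wide uncertainty in both directions.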

Compound 3, a percentage reported as inhibition, in the whole organism at one dose (the size of the read-out at that dose, not a potency): -54.4%
The estimate for compound 3 lay 79.4 percentage points above the measured number, outside the stated range (below it).
By their numbers in this assay, from the lowest: compound 3; then compound 1; then compound 2.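

Going by these compounds alone, the exchange of methyl for phenyl on an aromatic carbon of the five-membered aromatic ring gives a number 89.9 percentage points lower from compound 2 to compound 3 (beyond the scatter) in this assay and is the first reading at this position, which the step on the aromatic nitrogen did not probe. Compound 3 gives -54.4% in this read-out, so the exchange does more than erase the reported inhibition: the number falls below zero, which neither compound 1 nor compound 2 showed. No measurement at hand bears on the reason for this step.

With only methyl and phenyl shown on this carbon, it remains open whether the drop belongs to phenyl in particular or appears with other groups as well, and an ethyl, a cyclopropyl or a hydroxymethyl group would help to separate these cases. Also open, going by these compounds, is whether phenyl on this carbon gives the same kind of result with tert-butyl rather than methyl on the aromatic nitrogen, and whether the negative number persists at other oral doses.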